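A few compounds are considered here, and "the series" means these few. Any claim that something is new, unique, unknown or untested is made for them only; others in the source may bear on it.

Measured so far:
compound 1 `O=C(Nc1cccc(-n2cc(-c3ccncc3)c(-c3ccc(Cl)c(O)c3)n2)c1)Nc1cccc(C(F)(F)F)c1`: 1910 nM
compound 2 `COc1cc(-c2nn(-c3cccc(NC(=O)Nc4cc(C(F)(F)F)cc(C(F)(F)F)c4)c3)cc2-c2ccncc2)ccc1Cl`: 711 nM
compound 3 `COc1cc(-c2nn(-c3cccc(NC(=O)c4cccc(C(F)(F)F)c4)c3)cc2-c2ccncc2)ccc1Cl`: 2460 nM

All three were run in a functional assay on SNB-19 cells (Homo sapiens) for inhibition, read by sulforhodamine B assay, with a stated time of 48 h; on this read-out lower numbers stand for stronger inhibition of growth and higher numbers for weaker inhibition of growth. Compound 3 stands with the highest of the three numbers. Compound 1 sits within the usual scatter of it, so the read-out does not separate these two. Compound 2 sits lower by more than the scatter, the only separation seen in the set so far. Compound 1 and compound 2 both carry a urea; compound 3 carries an amide.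

Compound 4 `COc1cc(-c2nn(-c3cccc(NC(=O)Nc4ccc(Cl)c(Cl)c4)c3)cc2-c2ccncc2)ccc1Cl` has not yet been measured. It differs from compound 3 in one place: (3,4-dichlorophenyl)amino in place of 3-(trifluoromethyl)phenyl on a carbonyl carbon. The change turns the amide of compound 3 into a urea, as carried by compound 1 and compound 2, though with its own substitution pattern. Given that compound 2 with 711 nM is the one number clearly apart from compound 3, a moderate move toward a lower number is expected against compound 3, a 2.6-fold lower number from compound 3 to compound 4 (0.41 log units; beyond the scatter). For compound 4 the estimate in this assay is 950 nM, with a range from 400 nM to 2500 nM.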

Compound 4, concentration for 50% growth inhibition: 1720 nM
The estimate for compound 4 lay 1.8-fold (0.26 log units) below the measured number; the range from low to high includes it.
By their numbers in this assay, from the lowest: compound 2; then compounds 4, 1 and 3 (each within the scatter of the next).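

In this assay, (3,4-dichlorophenyl)amino in place of 3-(trifluoromethyl)phenyl on a carbonyl carbon gives a 1.4-fold lower number from compound 3 to compound 4 (0.16 log units; within the scatter), so the read-out does not separate this pair. This is the only pair in the series with a listed one-place step, and it shows that this exchange, which turns the amide into a urea and adds a hydrogen-bond donor, is not enough on its own to produce a difference beyond the scatter in this assay. No measured data bear on why the change leaves the read-out within the scatter.

The step changes the link and the ring substituents together, so the compounds shown leave open what each change does alone; an amide carrying 3,4-dichlorophenyl, or a urea carrying 3-(trifluoromethyl)phenyl on the core of compound 3, would separate the two. Also open, from the compounds shown here alone, is how the read-out responds at this position to a link that is neither amide nor urea, such as a sulfonamide, or to a morpholine in place of the aryl group.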